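The source may report more compounds than this note shows. Statements on the series, on what has been measured and on what is new or still open speak of the compounds shown alone.

Measured so far:
- Compound 1 `CC(C)(C)c1ccc(C(=O)NCc2ccc(C(N)=O)cc2)cc1` in an assay on HeLa cells with Bile acid receptor (Homo sapiens) as the target, read by a luciferase reporter, with a stated time of 24 h (a lower number here means that less compound is needed, a higher number that more compound is needed for the effect), gives 3800 nM.
- Compound 2 `CC(C)(C)c1ccc(C(=O)NCc2ccc(NC(=O)C(F)(F)F)cc2Cl)cc1` gives 14 nM in this assay.
- Compound 3 `O=C(O)c1ccc(CNC(=O)c2ccc3ccccc3c2)cc1` gives 1360 nM in this assay.

Among these three, compound 1 stands at the highest number, so it needs the most compound for the effect. Its nearest neighbour in this assay is compound 3, whose value is lower by a margin beyond the usual scatter, and compound 2 lies far below both.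

The next compound, compound 4 `C[S+]([O-])c1ccc(CNC(=O)c2ccc(C(C)(C)C)cc2)cc1`, has not yet been measured. It differs from compound 1 in one place: a group of 3 heavy atoms (1 carbon, 1 oxygen, 1 sulfur; no ring) in place of a group of 3 heavy atoms (1 carbon, 1 nitrogen, 1 oxygen; no ring), on an aromatic carbon. The shared core of compound 1 and compound 4 is otherwise untouched.

Going by the values given here, no pair of measured compounds differing in just one place is available, so the size of this step in this assay has to be judged from the change alone. Both groups are small and sit at the same spot on the ring; one hydrogen-bond donor is lost. Compound 3, carrying a different small group at that same place, gives 1360 nM, which hints that groups here can shift the number but not by a great deal. He therefore expects a step from compound 1 to compound 4 of a 1.3-fold lower number from compound 1 to compound 4 (0.10 log units; within the scatter), in either direction and possibly not beyond the scatter. His estimate for compound 4 in this assay is 3000 nM, within a range from 800 nM to 12000 nM.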

Compound 4, half-maximal effective concentration: 1300 nM
Estimate against measurement, compound 4: 2.3-fold (0.36 log units) above, within the range that was stated.
By their numbers in this assay, from the lowest: compound 2; then compounds 4 and 3 (each within the scatter of the next); then compound 1.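

In this assay, putting the group of 1 carbon, 1 oxygen and 1 sulfur in place of the carbamoyl group, on an aromatic carbon para to a large group, gives a 2.9-fold lower number from compound 1 to compound 4 (0.47 log units; beyond the scatter). Going by these compounds alone, this is the first step here that can be read from a change in one place, and it shows that this position is not indifferent to what it carries, even when the exchange keeps the number of heavy atoms and of hydrogen-bond acceptors the same and only removes the hydrogen-bond donor. The step is modest, and no measurement at hand bears on why the number moves.

A single step cannot separate the loss of the hydrogen-bond donor from the arrival of the sulfur-bearing group, so either could go with the lower number. On these data alone, how an amine or a nitrile at this place would compare remains open, as does whether the same exchange would shift the number by a similar amount on a different core.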